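Compound 2 to compound 3: benzyl leaves, amino enters

The source may hold more compounds than are shown below. What is called first, only, known or untested is meant among the compounds shown, and "the series" means these compounds.

Measured in a functional assay on HCT-116 cells (Homo sapiens) for inhibition, read by sulforhodamine B assay, with a stated time of 2 days; on this read-out higher numbers stand for weaker inhibition of growth and lower numbers for stronger inhibition of growth:
Compound 1 `CC1=C(C(=O)Nc2ccc(C)cc2)C(c2ccc(O)cc2O)NC(NCc2ccccc2)=N1` gives 66700 nM
Compound 2 `CC1=C(C(=O)Nc2cccc([N+](=O)[O-])c2)C(c2ccc(O)cc2O)NC(NCc2ccccc2)=N1` gives > 100000 nM as a limit of the assay

Compound 2 stands at the limit of > 100000 nM in this assay, at which 1 of the 2 values shown sits, and so has a limit rather than a number. Compound 3 `CC1=C(C(=O)Nc2cccc([N+](=O)[O-])c2)C(c2ccc(O)cc2O)NC(NN)=N1` differs from compound 2 in one place amino in place of benzyl on an amine nitrogen and carries amino in place of benzyl on an amine nitrogen. Within the data shown here, the one measured step is an at least 1.4-fold higher number from compound 1 to compound 2 (0.17 log units; that floor lies within the scatter) and it concerns 3-nitrophenyl in place of 4-methylphenyl on an amide-type nitrogen. Among the measured compounds shown here, that step does not touch the benzyl group, so no measured step bears directly on this change. In this assay, as far as these compounds go, no step beyond the scatter is expected, since compound 2 gives > 100000 nM as a limit and the direction stays open. The estimated step is an at least 1.2-fold lower number from compound 2 to compound 3 (0.09 log units; that floor lies within the scatter) and is expected to be small. Another limit is about as likely as a number. For compound 3 the expected value is 80000 nM with an estimated range from 25000 nM to 200000 nM in this assay.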

Compound 3, concentration for 50% growth inhibition: 47700 nM
Estimate against measurement, compound 3: 1.7-fold (0.22 log units) above; low and high end bracket the measured number.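

In this assay, the amine nitrogen gives the first single change among the compounds shown with a step beyond the scatter: an at least 2.0-fold lower number from compound 2 to compound 3 (0.32 log units; beyond the scatter). The step is only a floor because compound 2 is held at a limit of the assay rather than a number: the limit of > 100000 nM in this assay, at which 1 of the 3 values shown sits. In this pair, replacing benzyl, with its 7 heavy atoms and six-membered aromatic ring, by the single nitrogen of amino does not raise the number, so the benzyl group is not needed for the growth inhibition seen with compound 3, which gives 47700 nM.

As far as these compounds go, this single pair cannot separate the loss of benzyl from the entry of amino, and the true size of the step stays unknown while compound 2 has no number. Also open, from the compounds shown here alone, are whether the same change holds with the 4-methylphenyl group of compound 1 on the amide-type nitrogen, and how a plain amine, a methyl group or a longer chain ending in a carboxylic acid would read at this position.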